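The source may report more compounds than this note shows. Statements on the series, on what has been measured and on what is new or still open speak of the compounds shown alone.

In a functional assay on U-937 cells (Homo sapiens) for cytotoxicity, read by MTT assay, with a stated time of 3 days (a lower number here means a stronger inhibitor, a higher number a weaker inhibitor), compound 1 `N#Cc1c(O)nc(SCc2nc3ccccc3[nH]2)nc1-c1ccccc1` gives 3.28 nM and compound 2 `N#Cc1c(Cl)nc(SCc2nc3ccccc3[nH]2)nc1-c1ccccc1` gives 4.46 nM while compound 3 `N#Cc1c(Nc2ccccn2)nc(SCc2nc3ccccc3[nH]2)nc1-c1ccccc1` gives 2.55 nM and so stands level with both within the scatter. Compound 4 `N#Cc1c(NC(N)=O)nc(SCc2nc3ccccc3[nH]2)nc1-c1ccccc1` follows from compound 3 through carbamoyl in place of pyridin-2-yl on a nitrogen on an aromatic ring in which carbamoyl takes the place of pyridin-2-yl on a nitrogen on an aromatic ring. Three measured swaps on an aromatic carbon bear on this, and all stayed within the scatter (a 1.3-fold lower number from compound 1 to compound 3 (0.11 log units; within the scatter) and a 1.7-fold lower number from compound 2 to compound 3 (0.24 log units; within the scatter) and a 1.4-fold higher number from compound 1 to compound 2 (0.13 log units; within the scatter)). Within the data shown here, none of them involves a ureido group, so the measured compounds offer no direct precedent. No step beyond the scatter is therefore expected in this assay from this change. The expected step is small (a 1.3-fold higher number from compound 3 to compound 4 (0.10 log units; within the scatter)). Compound 4 is estimated at 3.2 nM with an expected range from 1.2 nM to 9 nM in this measurement.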

Compound 4, half-maximal inhibitory concentration: 3.37 nM
Estimate against measurement, compound 4: 1.1-fold (0.02 log units) below; low and high end bracket the measured number.
By their numbers in this assay, from the lowest: compounds 3, 1, 4 and 2 (each within the scatter of the next).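

Ureido on this aromatic carbon also stays within the scatter of every earlier group in this assay (a 1.3-fold higher number from compound 3 to compound 4 (0.12 log units; within the scatter); a 1.3-fold lower number from compound 2 to compound 4 (0.12 log units; within the scatter); a 1.0-fold higher number from compound 1 to compound 4 (0.01 log units; within the scatter)). The first of these steps shows that carbamoyl can take the place of pyridin-2-yl on the nitrogen, so the ring is given up with no step beyond the scatter. Hydroxy, chloro, (pyridin-2-yl)amino and ureido thus stand level here, and nothing measured explains why. From the compounds shown here alone, whether a primary amine or a carboxylic acid on this carbon would also stay level remains open. So does the effect of a longer chain on the nitrogen.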